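The compounds below may be only part of what the source reports. "The series", "measured", "known", "first", "only" and "open" are said of these compounds alone.

In a functional assay on MGC-803 cells (Homo sapiens) for antiproliferative activity, read by CCK-8 assay, with a stated time of 72 h, tested at 2 uM (on this read-out lower numbers stand for a weaker effect and higher numbers for a stronger effect at the one concentration tested), compound 1 `CCN(Cc1ccncc1)C(=S)SCc1ccc(C(=O)Nc2ccccc2N)cc1` gives 71.6%, compound 2 `CN(Cc1cccnc1)C(=S)SCc1ccc(C(=O)Nc2ccccc2N)cc1` gives 45.9% and compound 3 `Nc1ccccc1NC(=O)c1ccc(CSC(=S)N2CCN(c3ccc(F)cc3)CC2)cc1` gives 18.8%, the lowest of the three numbers; compound 2 stands nearest to it and compound 1 furthest, both gaps beyond the scatter. For the measured compounds named here, the one measured step, a number 25.7 percentage points lower from compound 1 to compound 2 (beyond the scatter), concerns the amino group on the thiocarbonyl carbon and not the six-membered aromatic ring of carbon only that compound 4 `N#Cc1ccc(N2CCN(C(=S)SCc3ccc(C(=O)Nc4ccccc4N)cc3)CC2)cc1` alters, so no measured step bears directly on the present change. Compound 4 differs from compound 3 as follows: cyano in place of fluoro on an aromatic carbon. Going by the values given here, with no comparable step to lean on, the expected step in this assay is a number 3.2 percentage points higher from compound 3 to compound 4 (within the scatter), that is none beyond the scatter. Compound 4 is therefore estimated at 22%, with a range from 5% to 45%.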

Compound 4, a percentage reported as inhibition, at one concentration (the size of the read-out at that concentration, not a potency): 34.5%
Compound 4: the middle estimate sits 12.5 percentage points below what was measured; the range from low to high includes it.
By their numbers in this assay, from the lowest: compound 3; then compound 4; then compound 2; then compound 1.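

In this assay, the change from 4-fluorophenyl to 4-cyanophenyl gives a number 15.7 percentage points higher from compound 3 to compound 4 (beyond the scatter), the first sign that this aromatic carbon, para to a large group, responds to the group it carries. The earlier compounds shown here showed only a step at the amino group on the thiocarbonyl carbon, so this aromatic ring had no measured step before. No evidence at hand accounts for the rise. Going by these compounds, whether an amine, a methoxy group or a carboxylic acid at this carbon would lift the number further remains open. So does whether cyano would give a similar step at another carbon of the ring.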